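Working notes on the oxazolidinone series: benzoate ester estimate

The source may report more compounds than this note shows. Statements on the series, on what has been measured and on what is new or still open speak of the compounds shown alone.

The shared core is seen in compound 1 `O=C1O[C@@H](CO)CN1c1ccc(-n2cc(-c3ccccn3)cn2)c(F)c1`, which in a physicochemical assay for lipophilicity, read by HPLC, measured as octanol-water partition (on this read-out higher numbers stand for higher lipophilicity and lower numbers for lower lipophilicity), gives 1.67. Compound 2 `COC(=O)CC1CCN(C[C@H]2CN(c3ccc(-n4cc(-c5ccccn5)cn4)c(F)c3)C(=O)O2)CC1` gives 1.78 in this assay, and compound 3 `O=C1O[C@@H](CN2CCC(c3ccc(F)cc3)CC2)CN1c1ccc(-n2cc(-c3ccccn3)cn2)c(F)c1` gives 5.78. On these three numbers compound 2 stands second highest: its nearest neighbour is compound 1, and the step of a number 0.11 log units higher from compound 1 to compound 2 (within the scatter) lies within the scatter; its furthest neighbour is compound 3, and the step of a number 4.00 log units higher from compound 2 to compound 3 (beyond the scatter) is large and beyond the scatter.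

Compound 4 `O=C(OC[C@H]1CN(c2ccc(-n3cc(-c4ccccn4)cn3)c(F)c2)C(=O)O1)c1ccccc1` is not yet measured. It differs from compound 2 by benzoyloxy in place of 4-((methoxycarbonyl)methyl)piperidin-1-yl on a saturated chain carbon bound to a saturated ring carbon. For the measured compounds named here, two measured steps bear on this place. The step from compound 1 to compound 2 shows that exchanging the group at this position need not move the number at all, whereas the step from compound 2 to compound 3 shows that an exchange at the same position can move it very far. Neither step contains the entering group, so the expected size of the step in this assay is taken between the two: an increase beyond the scatter, but well short of the large one. Compound 4 is therefore expected at 3.5, within 2.8 to 4.2, which means an estimated step of a number 1.72 log units higher from compound 2 to compound 4 (beyond the scatter).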

Compound 4, partition coefficient: 4.21
For compound 4 the middle estimate is 0.71 log units below the measured one; measured number above the stated range.
By their numbers in this assay, from the lowest: compounds 1 and 2 (each within the scatter of the next); then compound 4; then compound 3.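

In this assay this place on a saturated chain carbon bound to a saturated ring carbon now gives a second large rise, with benzoyloxy in place of 4-((methoxycarbonyl)methyl)piperidin-1-yl: a number 2.43 log units higher from compound 2 to compound 4 (beyond the scatter), and here the entering group holds no ring nitrogen. Set against the hydroxy of the core, benzoyl in place of hydrogen on the oxygen gives a number 2.54 log units higher from compound 1 to compound 4 (beyond the scatter), whereas the larger group of compound 2 gave only a number 0.11 log units higher from compound 1 to compound 2 (within the scatter), so among these four compounds group size alone does not track the number, and the two large rises at this place, in compound 3 and compound 4, both come with a six-membered aromatic ring of carbon only in the entering group. The data shown offer no explanation for the size of either step.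

Still open, on these data alone, is whether the aromatic ring alone goes with the rise or the ester link also contributes, which a benzyl ether or an acetate at the same place would separate. Also open, as far as these compounds go, is how the number responds to a carboxylic acid in place of the methyl ester of compound 2, or to a basic amine on a longer chain.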